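Solubility of a Fused-Ring Amine Replacing a Phenoxy Group

The source may report more compounds than this note shows. Statements on the series, on what has been measured and on what is new or still open speak of the compounds shown alone.

Compound 1 `COc1ccc2[nH]c(C(=O)N3CC(=O)N(Cc4ccccc4)[C@@H](COc4ccccc4)C3)cc2c1` belongs to a small set of three compounds measured in a physicochemical assay for solubility, read by spectrophotometry, in phosphate buffer, with a stated time of 2 h, at pH 7.4; on this read-out higher numbers stand for higher solubility and lower numbers for lower solubility. In this assay compound 1 gives 12200 nM, the second highest of the three numbers. Its nearest neighbour is compound 3 `COc1ccc2[nH]c(C(=O)N3CC(=O)N(Cc4cccc(OC(F)F)c4)[C@@H](CN4CCC(c5ccccn5)CC4)C3)cc2c1`, which gives 11600 nM, a difference well within the usual scatter. The furthest is compound 2 `COc1ccc2[nH]c(C(=O)N3CC(=O)N(Cc4ccoc4)[C@@H](Cc4ccccc4)C3)cc2c1`, which gives 63600 nM, a gap beyond the scatter.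

Compound 4 `COc1ccc2[nH]c(C(=O)N3CC(=O)N(Cc4ccccc4)[C@@H](CN4CCn5cccc5C4)C3)cc2c1` has not yet been measured in this assay. It differs from compound 1 in one place: a group of 9 heavy atoms (7 carbon, 2 nitrogen; one five-membered aromatic ring with 1 hetero atom, one six-membered non-aromatic ring with 2 hetero atoms) in place of a group of 7 heavy atoms (6 carbon, 1 oxygen; one six-membered aromatic ring of carbon only), on a saturated chain carbon bound to a saturated ring carbon. The group that enters is a fused system of one five-membered aromatic ring with one hetero atom and one six-membered non-aromatic ring with two hetero atoms, in place of a phenoxy group.

Among the compounds with values here, no pair of measured compounds differs by such a change, so the size of this step cannot be read from the data. Compound 3 carries a different nitrogen-containing ring on the same chain position and gives 11600 nM, close to compound 1, which argues against a large shift. A modest rise is expected, with the step from compound 1 to compound 4 estimated at a 1.8-fold higher number from compound 1 to compound 4 (0.26 log units; within the scatter). Compound 4 is therefore estimated at 22000 nM, with a range from 8000 nM to 70000 nM.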

Compound 4, solubility: 29700 nM
For compound 4 the middle estimate is 1.4-fold (0.13 log units) below the measured one; the range from low to high includes it.
By their numbers in this assay, from the lowest: compounds 3 and 1 (each within the scatter of the next); then compound 4; then compound 2.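

Within the data shown here, compound 1 and compound 4 form the first pair in this set that differs in one place only, so the effect of a single change at this position can now be read directly. In this assay, putting the fused system of a five-membered aromatic ring and a six-membered non-aromatic ring in place of the phenoxy group gives a 2.4-fold higher number from compound 1 to compound 4 (0.39 log units; beyond the scatter). The position, on a saturated chain carbon bound to a saturated ring carbon, is therefore one where exchanging a single group can move this read-out by more than repeat measurements would, although nothing available here explains why the number moved.

This single step replaces a whole group, so it cannot show whether the rise goes with the loss of the phenoxy group, with the five-membered aromatic ring, or with the six-membered non-aromatic ring that carries the nitrogen atoms. On these data alone, how a smaller dimethylamino group, a morpholine ring or a carboxylic acid on the same carbon would compare with compound 1 remains open, as does whether any such step would match this one in direction or size.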